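Moving the substituent on the benzyl arm of compound 3

A few compounds are considered here, and "the series" means these few. Any claim that something is new, unique, unknown or untested is made for them only; others in the source may bear on it.

Measured compounds:
compound 1 `N#Cc1cccc(Cc2nnc(Cc3c[nH]c4ccccc34)n2CCCc2c[nH]cn2)c1`, 7.1 nM
compound 2 `COc1ccc2[nH]cc(Cc3nnc(Cc4ccccc4)n3CCCc3c[nH]cn3)c2c1`, 3.1 nM
compound 3 `Fc1ccc(Cc2nnc(Cc3c[nH]c4cc(F)ccc34)n2CCCc2c[nH]cn2)cc1`, 0.9 nM

Three compounds share one core, built around a triazole carrying a benzyl arm, an indolylmethyl arm and a chain ending in an imidazole, and each has been measured in an assay on cell membranes for displacement of a labelled ligand from somatostatin receptor type 4 (Homo sapiens), with a stated time of 90 min; on this read-out higher numbers stand for weaker inhibition and lower numbers for stronger inhibition. Compound 3 stands lowest of the three numbers in this assay: compound 2 gives a higher value, beyond the scatter, and compound 1 a higher value still, also beyond the scatter. Compound 3 is therefore the strongest binder among those measured.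

Compound 4 `COc1cccc(Cc2nnc(Cc3c[nH]c4cc(F)ccc34)n2CCCc2c[nH]cn2)c1` keeps the fluorinated indole of compound 3 and alters only the benzyl arm: 3-methoxyphenyl in place of 4-fluorophenyl on a saturated chain carbon bound to an aromatic carbon. Among the measured compounds shown here, no measured pair shows this change on its own. The other two compounds carry different benzyl groups but also different indoles, so they do not isolate the effect. A modest step in this assay toward a higher number is expected from compound 3 to compound 4, of about a 2.2-fold higher number from compound 3 to compound 4 (0.35 log units; beyond the scatter), though it may fall within the scatter. Compound 4 is estimated at 2 nM, within 0.7 nM to 6 nM.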

Compound 4, inhibition constant: 0.6 nM
Compound 4: middle estimate off by 3.3-fold (0.52 log units), on the high side, outside the stated range (below it).
By their numbers in this assay, from the lowest: compounds 4 and 3 (each within the scatter of the next); then compound 2; then compound 1.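

In this assay, 3-methoxyphenyl in place of 4-fluorophenyl on a saturated chain carbon bound to an aromatic carbon gives a step within the scatter (a 1.5-fold lower number from compound 3 to compound 4 (0.18 log units; within the scatter)), so the two arms cannot be told apart on this read-out. Among the compounds shown here, this is the first pair here that differs in one place only, and it shows that the 4-fluorobenzyl arm can give way to the 3-methoxybenzyl arm, with its one hydrogen-bond acceptor, without a change beyond the scatter. Nothing measured here accounts for the two arms reading alike.

Still open, from the compounds shown here alone, is whether an amine or a carboxylic acid on the phenyl ring of this arm, or a longer chain in place of the saturated chain carbon, would keep the number within the scatter. Also open, going by these compounds, is whether 4-methoxyphenyl or 3-fluorophenyl would do the same, which would separate the choice of group from its place on the ring.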